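Chloro in Place of Hydroxy on the Pendant Phenyl

This account rests on a few compounds, and the source may have more. Where it says the series, first, only, none or still open, it means among the compounds named here.

Of the compounds shown here, three built on a shared core have been measured in an assay on cells for displacement of a labelled ligand from adenosine receptor A1 (Homo sapiens), read by scintillation counting and radioligand binding, with a stated time of 60 min, tested at 10 uM; on this read-out lower numbers stand for less inhibition and higher numbers for more inhibition at the one concentration tested (going by the name of the read-out). Compound 1 `CN1CCN(c2nc(-c3ccc(Cl)cc3)nc3[nH]cnc23)CC1` reaches the limit of the assay, > 80%, not a number. Compound 2 `Clc1ccc(-c2nc(N3CCCCC3)c3nc[nH]c3n2)cc1Cl` gives 24.1%. On these data alone, compound 3 `Oc1ccc(-c2nc(N3CCCCC3)c3nc[nH]c3n2)cc1` also stands at the limit, > 80%, so its true inhibition is unknown; this is part of the limit of > 80% in this assay, at which 2 of the 3 values shown sit. Going by the values given here, no step between measured compounds is available. Compound 4 `Clc1ccc(-c2nc(N3CCCCC3)c3nc[nH]c3n2)cc1` is still unmeasured; it differs from compound 3 by chloro in place of hydroxy on an aromatic carbon. Compound 4 is expected to sit somewhat lower than compound 3, a step of a number at least 20 percentage points lower from compound 3 to compound 4 (beyond the scatter) beyond the scatter. The estimate for compound 4 in this assay is 60%, within 25% to 90%.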

Compound 4, a percentage reported as inhibition, at one concentration (the size of the read-out at that concentration, not a potency): > 80%
Compound 4: only a limit was reported; the forecaster's own chance of this, stated with the estimate: 35%; middle value at least 20 percentage points away from the limit.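

In this assay compound 4 gives > 80%, a limit of the assay and not a number. Hydrogen in place of one chloro on the aromatic ring gives a number at least 55.9 percentage points higher from compound 2 to compound 4 (beyond the scatter), so the low reading goes with the second chloro and not with the one that remains. The other two steps cannot be read, because of the limit: the limit of > 80% in this assay, at which 3 of the 4 values shown sit.

On these data alone, whether chloro and hydroxy differ at all at this place stays open. So does how an amine or a carboxylic acid on the same aromatic carbon would read in this assay.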